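Swapping Nitro for Amino on a Cytotoxic Quinone

A few compounds are considered here, and "the series" means these few. Any claim that something is new, unique, unknown or untested is made for them only; others in the source may bear on it.

- compound 1 `COC1=CC(=O)c2c(c(COc3cccc([N+](=O)[O-])c3)c(C)n2C)C1=O`: 352 nM
- compound 2 `COC1=CC(=O)c2c(c(COc3ccc([N+](=O)[O-])cc3F)c(C)n2C)C1=O`: 4650 nM
- compound 3 `COC1=CC(=O)c2c(COc3ccc([N+](=O)[O-])cc3)c(C)n(C)c2C1=O`: 638 nM

These three compounds were tested in a functional assay on MIA PaCa-2 cells (Homo sapiens) for cytotoxicity, read by MTT assay, with a stated time of 4 h; a lower number here means a stronger inhibitor, a higher number a weaker inhibitor. There, compound 3 gives 638 nM, which lies within the usual scatter of compound 1 at 352 nM. Compound 2, at 4650 nM, is clearly the weaker of the pair formed with compound 3.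

Compound 4 `COC1=CC(=O)c2c(COc3ccc(N)cc3)c(C)n(C)c2C1=O` differs from compound 3 by one change: amino in place of nitro on an aromatic carbon, para to a large group (amino in place of nitro on an aromatic carbon).

Among the measured compounds shown here, all three measured compounds carry a nitro group, so no measured pair shows this swap directly. For the measured compounds named here, the values of compound 1 at 352 nM and compound 2 at 4650 nM show only that numbers in this small set can lie far apart. A wide range is therefore warranted. A moderate move towards weaker inhibition is expected, with a 1.9-fold higher number from compound 3 to compound 4 (0.27 log units; within the scatter) as the estimated step. For compound 4 the estimated value is 1200 nM, with an expected range of 300 nM to 5000 nM.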

Compound 4, half-maximal inhibitory concentration: 504 nM
For compound 4 the middle estimate is 2.4-fold (0.38 log units) above the measured one; the measured number falls inside the stated range.
By their numbers in this assay, from the lowest: compounds 1, 4 and 3 (each within the scatter of the next); then compound 2.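

In this assay the swap of nitro for amino on an aromatic carbon, para to a large group, gives a 1.3-fold lower number from compound 3 to compound 4 (0.10 log units; within the scatter) and so shows that this position tolerates the change. Among the compounds shown here, compound 4 has no nitro group yet stays level with compound 3, something the earlier compounds could not show, as all of them carry nitro. Nothing measured here explains why the two groups give such similar numbers.

The compounds shown leave open whether other groups at this place, such as a methoxy group, a carboxylic acid or a dimethylamino group, would also keep the number level. They also leave open whether the same swap of nitro for amino on compound 1 or compound 2 would give a similarly small step.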